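The source may report more compounds than this note shows. Statements on the series, on what has been measured and on what is new or still open speak of the compounds shown alone.

Compound 1 `COc1ccc(-c2cc(/C=C/C(=O)c3ccc(OC)c(OC)c3)[nH]n2)cc1`: 2160 nM
Compound 2 `COc1cc(-c2cc(/C=C/C(=O)c3ccc(Cl)c(Cl)c3)[nH]n2)cc(OC)c1OC`: 6300 nM
Compound 3 `COc1cc(C(=O)/C=C/c2cc(-c3cc(OC)c(OC)c(OC)c3)n[nH]2)cc(OC)c1OC`: 1580 nM

Of the compounds shown here, three have been tested in a functional assay on OVCAR-8 cells (Homo sapiens) for inhibition, read by sulforhodamine B assay, with a stated time of 48 h; a higher number here means a weaker inhibitor of growth, a lower number a stronger inhibitor of growth. Compound 2 stands highest of the three numbers with 6300 nM. Its nearest neighbour is compound 1, which in this assay gives 2160 nM, a gap beyond the scatter; furthest is compound 3, which gives 1580 nM, also beyond the scatter. No pair among these three differs in only one place, so no single step between measured compounds can be read off.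

Compound 4 `COc1cc(-c2cc(/C=C/C(=O)c3ccc(F)c(F)c3)[nH]n2)cc(OC)c1OC` has not yet been measured in this assay. It differs from compound 2 in one place: 3,4-difluorophenyl in place of 3,4-dichlorophenyl on a carbonyl carbon. Within the data shown here, since no measured pair shows the effect of exchanging these two halogen-bearing rings, the step is expected to be small, in either direction, most likely within the scatter. Compound 4 is therefore estimated at 5000 nM, with a range from 1500 nM to 16000 nM, a step of a 1.3-fold lower number from compound 2 to compound 4 (0.10 log units; within the scatter) that is not expected to exceed the scatter.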

Compound 4, concentration for 50% growth inhibition: 2880 nM
Compound 4: middle estimate off by 1.7-fold (0.24 log units), on the high side; measured number inside the range.
By their numbers in this assay, from the lowest: compounds 3, 1 and 4 (each within the scatter of the next); then compound 2.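

In this assay, among these compounds, the exchange of 3,4-dichlorophenyl for 3,4-difluorophenyl on a carbonyl carbon gives the first step that can be read between two measured compounds (a 2.2-fold lower number from compound 2 to compound 4 (0.34 log units; beyond the scatter)). The step is modest but beyond the scatter, so the two halogen-bearing rings are not interchangeable at this position, even though the change leaves the count of heavy atoms the same. No measurement shown here explains the step.

Compound 1 and compound 3 each differ from compound 4 in more than one place, so they do not show how a methoxy-bearing ring on the carbonyl carbon compares with the halogen-bearing rings. Going by these compounds, it also remains open how this position would respond to an unsubstituted phenyl, or to a phenyl carrying a nitrile or a dimethylamino group.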